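The source may hold more compounds than are shown below. What is called first, only, known or untested is meant among the compounds shown, and "the series" means these compounds.

Measured so far:
compound 1 `ClCc1ccc(Cn2cnc3c(Cl)ncnc32)cc1` — 74100 nM
compound 2 `ClCc1ccccc1Cn1cnc2c(Cl)nc(Cl)nc21` — 4260 nM

In a functional assay on SK-MEL-5 cells (Homo sapiens) for cytotoxicity, read by sulforhodamine B assay, with a stated time of 48 h (a lower number here means that less compound is tolerated, a higher number that more compound is tolerated), compound 2 gives 4260 nM, the lowest of the two numbers; compound 1 gives 74100 nM, a gap beyond the scatter. Going by the values given here, the two differ in more than one place, so no single step is defined between them. Compound 3 `ClCc1ccccc1Cn1cnc2c(Cl)ncnc21` is derived from compound 2 by hydrogen in place of chloro on an aromatic carbon. Among the compounds with values here, no comparable step has been measured in this assay, so the expectation rests on the two values alone: a higher number is expected, a step of moderate size beyond the scatter, a 4.7-fold higher number from compound 2 to compound 3 (0.67 log units; beyond the scatter). For compound 3 the estimate in this assay is 20000 nM, with a range from 5000 nM to 80000 nM.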

Compound 3, concentration lethal to 50% of the cells: 5880 nM
The estimate for compound 3 lay 3.4-fold (0.53 log units) above the measured number; the range from low to high includes it.
By their numbers in this assay, from the lowest: compounds 2 and 3 (each within the scatter of the next); then compound 1.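

In this assay the step of a 1.4-fold higher number from compound 2 to compound 3 (0.14 log units; within the scatter) puts hydrogen in place of chloro on an aromatic carbon between two ring nitrogen atoms, and it stays within the scatter. This first single-place step in the series shows that, for this pair, the chloro group at this position can be lost without a difference beyond the scatter. No measured evidence bears on the reason for this result.

Still open, as far as these compounds go, is whether a different group at this position, such as an amine or a methoxy group, would give a step beyond the scatter.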